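Extending an Alkyl Chain: Expected Lipophilicity of Compound 4

The source may hold more compounds than are shown below. What is called first, only, known or untested is meant among the compounds shown, and "the series" means these compounds.

Of the compounds shown here, three have so far been measured in a physicochemical assay for lipophilicity; on this read-out higher numbers stand for higher lipophilicity and lower numbers for lower lipophilicity. Compound 1 `CCCOc1ccc2[nH]c(-c3ccccc3)c(C3=C(Br)C(=O)NC3=O)c2c1` gives 3.16 in this assay. Compound 2 `CCCCCOc1ccc2[nH]c(-c3ccccc3)c(C3=C(Br)C(=O)NC3=O)c2c1` gives 3.75 in this assay. The two differ in one place only, (ethyl in place of hydrogen on a saturated chain carbon, three bonds along the chain from an oxygen on an aromatic ring), and the step between them is a number 0.59 log units higher from compound 1 to compound 2 (beyond the scatter).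

Compound 3 `CCCCc1cccc2c(C3=C(Br)C(=O)NC3=O)c(-c3ccc(OC)cc3)[nH]c12` is built on a different core; how its core differs from that of compound 1 is not broken down here. In this assay compound 3 gives 3.81, the highest of the three numbers; its gap to compound 2 lies within the usual scatter, while its gap to compound 1 lies beyond it.

Compound 4 `CCCCCCc1cccc2c(C3=C(Br)C(=O)NC3=O)c(-c3ccc(OC)cc3)[nH]c12` has not yet been measured. It differs from compound 3 by ethyl in place of hydrogen on a saturated chain carbon, four bonds along the chain from an aromatic carbon. Within the data shown here, this is the same kind of change as the one between compound 1 and compound 2, though not the same: in that pair the place is three bonds along the chain from an oxygen on an aromatic ring, whereas here it is four bonds along the chain from an aromatic carbon. Because the earlier step was a number 0.59 log units higher from compound 1 to compound 2 (beyond the scatter), a step of similar size is expected for compound 4, namely a number 0.59 log units higher from compound 3 to compound 4 (beyond the scatter). Compound 4 is therefore estimated to give 4.4 in this assay, with a likely range from 4.05 to 4.75.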

Compound 4, partition coefficient: 4.27
Compound 4: the middle estimate sits 0.13 log units above what was measured; measured number inside the range.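

In this assay, the same kind of change moves the number the same way on both cores: the first core shows a number 0.59 log units higher from compound 1 to compound 2 (beyond the scatter), and the core of compound 3 shows a number 0.46 log units higher from compound 3 to compound 4 (beyond the scatter). This suggests that the direction and the modest size of the step carried from one core to the other in this one case, but two steps cannot establish a general rule, and they are not strictly the same change: the first lies three bonds along the chain from an oxygen on an aromatic ring, the second four bonds along the chain from an aromatic carbon, so the effect of the core cannot be separated from the effect of the place. Nothing available bears on why the two steps take the sizes they do.

The compounds shown leave open whether the number keeps rising with a longer chain at the same place on either core. They also leave open how an amine or a carboxylic acid in place of ethyl would read, and whether such a change would carry from one core to the other as this one did.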